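The compounds below may be only part of what the source reports. "The series", "measured", "known", "first", "only" and "open" are said of these compounds alone.

Measured compounds:
compound 1 `COc1cc(N(C)CCN(C)C)c(NC(=O)/C=C\C(C)C)cc1Nc1nccc(-c2cn(C)c3ccc(F)cc23)n1` — 6140 nM
compound 2 `C=CC(=O)Nc1cc(Nc2nc(C)cc(-c3cn(C)c4ccc(F)cc34)n2)c(OC)cc1N(C)CCN(C)C` — 1490 nM
compound 3 `CC/C=C\C(=O)Nc1cc(Nc2nc(C)cc(-c3cn(C)c4ccc(F)cc34)n2)c(OC)cc1N(C)CCN(C)C` — 9150 nM

In a functional assay on A549 cells (Homo sapiens) for antiproliferative activity, read by MTT assay, with a stated time of 72 h (on this read-out higher numbers stand for weaker inhibition and lower numbers for stronger inhibition), compound 3 gives the highest of the three numbers. Its nearest neighbour is compound 1, which in this assay gives 6140 nM, a gap within the scatter; the furthest is compound 2, which gives 1490 nM, a gap beyond the scatter.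

Compound 4 `COc1cc(N(C)CCN(C)C)c(NC(=O)/C=C\C(C)C)cc1Nc1nc(C)cc(-c2cn(C)c3ccc(F)cc23)n1` differs from compound 3 by methyl in place of hydrogen on a saturated chain carbon bound to a double-bonded chain carbon and a saturated chain carbon. Cut one bond further out, this reads but-1-en-1-yl to 3-methylbut-1-en-1-yl on the amide carbonyl.

Among the measured compounds shown here, the one measured step, a 6.1-fold higher number from compound 2 to compound 3 (0.79 log units; beyond the scatter), concerns a different change (vinyl to but-1-en-1-yl) and does not test a methyl added to the saturated chain carbon. Compound 1 carries the same (3-methylbut-1-en-1-yl)carbonyl amide as compound 4 but differs from it elsewhere, so no listed step isolates the change. The values of compound 1 and compound 3 lie within the scatter of each other, which is the only indirect hint.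

For compound 4 in this assay the expectation is therefore no step beyond the scatter, a 1.1-fold lower number from compound 3 to compound 4 (0.03 log units; within the scatter), and the estimate is 8500 nM, with a range of 3500 nM to 20000 nM.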

Compound 4, half-maximal inhibitory concentration: 9080 nM
Beside the measured number, compound 4's estimate is 1.1-fold (0.03 log units) below it, within the range that was stated.
By their numbers in this assay, from the lowest: compound 2; then compounds 1, 4 and 3 (each within the scatter of the next).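

In this assay, among the compounds shown here, the methyl on the saturated chain carbon bound to a double-bonded chain carbon and a saturated chain carbon is now tested directly: with a 1.0-fold lower number from compound 3 to compound 4 (0.00 log units; within the scatter), ethyl to isopropyl at the chain end gives no step that can be told from the scatter. Compound 2 with its vinyl group remains set apart, since a 6.1-fold higher number from compound 2 to compound 4 (0.78 log units; beyond the scatter) stands beyond the scatter, as does a 6.1-fold higher number from compound 2 to compound 3 (0.79 log units; beyond the scatter), so both longer alkenyl groups on the carbonyl carbon, but-1-en-1-yl and 3-methylbut-1-en-1-yl, keep the modest step from vinyl. The second single change, methyl in place of hydrogen on an aromatic carbon, also stays within the scatter, with a 1.5-fold higher number from compound 1 to compound 4 (0.17 log units; within the scatter) as the printed step, which means neither methyl shows a measurable step in this set.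

Nothing available accounts for these numbers. Open, on these data alone, is whether a dimethylamino group, a hydroxyl group or a phenyl ring on that saturated chain carbon, in place of methyl, would give a step beyond the scatter, and whether a longer chain there would do the same.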